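Leaving the Sulfamoylphenyl Behind: Expecting a Return to the Limit

This account rests on a few compounds, and the source may have more. Where it says the series, first, only, none or still open, it means among the compounds named here.

Going by the values given here, compound 3 `N#CC1=C(N)Oc2c(c3nc4ccccc4nc3c3ccccc23)C12C(=O)N(Cc1cnnn1-c1ccc(S(N)(=O)=O)cc1)c1ccccc12` is the one member of this small set for which a functional assay on HCT-116 cells (Homo sapiens) for antiproliferative activity, read by MTT assay, with a stated time of 48 h (a higher number here means a weaker inhibitor, a lower number a stronger inhibitor), returns a number: compound 3 gives 31200 nM. Compound 1 `N#CC1=C(N)Oc2c(c3nc4ccccc4nc3c3ccccc23)C12C(=O)N(Cc1cnnn1-c1ccc(F)cc1)c1ccccc12` reaches only the limit of the assay, with compound 1 at > 50000 nM. Compound 2 `CCOc1ccccc1-n1nncc1CN1C(=O)C2(C(C#N)=C(N)Oc3c2c2nc4ccccc4nc2c2ccccc32)c2ccccc21` likewise sits at the limit, compound 2 giving > 50000 nM. The whole picture is shaped by the limit of > 50000 nM in this assay, at which 2 of the 3 values shown sit. Among the compounds with values here, compound 3 thus stands alone as the only readable value; the step of an at least 1.6-fold lower number from compound 1 to compound 3 (0.20 log units; that floor lies within the scatter) and the step of an at least 1.6-fold lower number from compound 2 to compound 3 (0.20 log units; that floor lies within the scatter) each run toward a lower number, though their floor lies within the scatter, and the step that the two limits leave unreadable from compound 1 to compound 2 cannot be read at all.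

Compound 4 `N#CC1=C(N)Oc2c(c3nc4ccccc4nc3c3ccccc23)C12C(=O)N(Cc1cnnn1-c1cc(Cl)ccc1Cl)c1ccccc12` differs from compound 3 in one place: 2,5-dichlorophenyl in place of 4-sulfamoylphenyl on an aromatic nitrogen. Within the data shown here, the 4-sulfamoylphenyl was the only group on that aromatic nitrogen that gave a readable number, while the 4-fluorophenyl and 2-ethoxyphenyl analogues both sit at the limit. Since both measured steps into compound 3 were at best modest, moving away from the 4-sulfamoylphenyl is expected to raise the number, most likely back to the limit. Compound 4 is therefore expected near 50000 nM, within 25000 nM to 100000 nM. That estimate means a 1.6-fold higher number from compound 3 to compound 4 (0.20 log units; within the scatter), with a strong chance that only a limit is reported.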

Compound 4, half-maximal inhibitory concentration: > 50000 nM
Compound 4: a limit, no number; the forecaster's own chance of this, stated with the estimate: 60%; the middle value lies on the limit itself.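

On these data alone, the change from 4-sulfamoylphenyl to 2,5-dichlorophenyl on this aromatic nitrogen gives an at least 1.6-fold higher number from compound 3 to compound 4 (0.20 log units; that floor lies within the scatter), and because that floor lies within the scatter, the true size of the step stays unknown. Compound 4 adds a third group at this position that returns no number in this assay, and this one carries two chlorine atoms and no hydrogen-bond donors or acceptors, unlike the fluoro and ethoxy groups of compound 1 and compound 2, so three differently substituted phenyl rings now behave alike, with compound 3 the lone exception. The steps among compound 1, compound 2 and compound 4 cannot be read, and one boundary still governs the series: the limit of > 50000 nM in this assay, at which 3 of the 4 values shown sit.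

As far as these compounds go, what remains open is whether the sulfamoyl group itself is what separates compound 3 from the others, or whether a phenyl ring carrying a carboxylic acid or an amine in its place would also give a readable number. Going by these compounds alone, with only one true number in hand, nothing here shows how far the activity at this position could move, and a plain unsubstituted phenyl would give a useful point of reference.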